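Replacing the 3-fluorophenoxy group of compound 1

The source may hold more compounds than are shown below. What is called first, only, known or untested is meant among the compounds shown, and "the series" means these compounds.

Compound 1 `Cn1ncc2c(=O)n(-c3ccccc3)c(COc3cccc(F)c3)nc21` is the starting point. In a physicochemical assay for solubility, using the shake flask method, in phosphate buffer, with a stated time of 24 h, at pH 7.4 (a lower number here means a less soluble compound, a higher number a more soluble compound), compound 1 gives 194000 nM, the higher of the two exact numbers available. Compound 2 `Cn1ccc2c(=O)n(-c3ccccc3)c(SCc3cccc(F)c3)nc21` gives 23000 nM in this assay, and that gap lies beyond the usual scatter. Compound 3 `Cn1ncc2c(=O)n(-c3ccccc3)c(SCc3cccc(F)c3)nc21` reads < 700 nM, which is a limit and not an exact number.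

Compound 4 `Cn1ncc2c(=O)n(-c3ccccc3)c(CNc3cccc(F)c3)nc21` has not been measured yet. It carries (3-fluorophenyl)amino in place of 3-fluorophenoxy on a saturated chain carbon bound to an aromatic carbon. Among the measured compounds shown here, no measured pair of compounds isolates this swap, so any forecast is uncertain. Compound 1 at 194000 nM stands at the top of the numbers seen so far, so a moderate drop in this assay, larger than the scatter, is the expected direction. The expected move is a 3.9-fold lower number from compound 1 to compound 4 (0.59 log units; beyond the scatter). For compound 4 the estimated value is 50000 nM, with an expected range from 8000 nM to 200000 nM.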

Compound 4, solubility: 64000 nM
Beside the measured number, compound 4's estimate is 1.3-fold (0.11 log units) below it; the range from low to high includes it.
By their numbers in this assay, from the lowest: compound 2; then compound 4; then compound 1. At a limit, below all of these: compound 3.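

In this assay, among the compounds shown here, this swap gives the first step that isolates a single change at this place, on a saturated chain carbon bound to an aromatic carbon: a 3.0-fold lower number from compound 1 to compound 4 (0.48 log units; beyond the scatter). The two groups have the same count of heavy atoms and the same aromatic ring, and they differ in that (3-fluorophenyl)amino has a hydrogen-bond donor and 3-fluorophenoxy has none. No measurement shown here bears on the reason for the step.

The compounds shown leave open whether the step follows the hydrogen-bond donor or the exchange of oxygen for nitrogen as such. An amine carrying a methyl group on its nitrogen, or a plain carbon chain at the same place, would help to separate the two.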